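A few compounds are considered here, and "the series" means these few. Any claim that something is new, unique, unknown or untested is made for them only; others in the source may bear on it.

Compound 1 `[O-][n+]1nc(NCOCc2ccccc2)[n+]([O-])c2ccccc21`: 4140 nM
Compound 2 `CCCCCOCNc1n[n+]([O-])c2ccccc2[n+]1[O-]`: 2900 nM
Compound 3 `CCCCCOCNc1n[n+]([O-])c2cc(OC)ccc2[n+]1[O-]`: 2510 nM

These three compounds were measured in a functional assay on A549 cells (Homo sapiens) for cytotoxicity, read by MTT assay, with a stated time of 72 h; on this read-out lower numbers stand for stronger inhibition and higher numbers for weaker inhibition. Compound 2 and compound 3 differ only in the core: compound 3 carries methoxy in place of hydrogen on an aromatic carbon, and the step of a 1.2-fold lower number from compound 2 to compound 3 (0.06 log units; within the scatter). Compound 1 differs from compound 2 by phenyl in place of butyl on a saturated chain carbon bound to an oxygen on a saturated carbon, and the step of a 1.4-fold higher number from compound 2 to compound 1 (0.15 log units; within the scatter). Compound 4 `COc1ccc2c(c1)[n+]([O-])nc(NCOCc1ccccc1)[n+]2[O-]` has not yet been measured in this assay. It pairs the core of compound 3 with the side chain of compound 1, so that it differs from compound 3 by phenyl in place of butyl on a saturated chain carbon bound to an oxygen on a saturated carbon, the same change that was made from compound 2 to compound 1. For the measured compounds named here, that earlier step is the only guide, and it stayed within the scatter, so compound 4 is expected to show a 1.4-fold higher number from compound 3 to compound 4 (0.14 log units; within the scatter). Compound 4 is therefore estimated at 3500 nM, with a likely range from 1800 nM to 7000 nM.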

Compound 4, half-maximal inhibitory concentration: 4470 nM
Compound 4: middle estimate off by 1.3-fold (0.11 log units), on the low side; measured number inside the range.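

Phenyl in place of butyl on the methoxy-bearing core gives a 1.8-fold higher number from compound 3 to compound 4 (0.25 log units; within the scatter), which agrees with the earlier step on the core without methoxy: the same change on two cores in this assay, a 1.4-fold higher number (0.15 log units; within the scatter) from compound 2 to compound 1 and a 1.8-fold higher number (0.25 log units; within the scatter) from compound 3 to compound 4, 1.2-fold (0.10 log units) apart, within the scatter of two such steps

Methoxy in place of hydrogen on an aromatic carbon gives a 1.1-fold higher number from compound 1 to compound 4 (0.03 log units; within the scatter), and this too agrees with its earlier step: the same change on two cores in this assay, a 1.2-fold lower number (0.06 log units; within the scatter) from compound 2 to compound 3 and a 1.1-fold higher number (0.03 log units; within the scatter) from compound 1 to compound 4, 1.2-fold (0.10 log units) apart, within the scatter of two such steps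

All of these steps lie within the scatter, so in this assay neither change can be told apart from repeat noise on either core, and the agreement does not show that a change with a clear effect would carry across cores in the same way.

The compounds shown leave open whether a side chain ending in an amine or a carboxylic acid, or one longer than pentyl, would move the number beyond the scatter. They also leave open what a chlorine in place of the methoxy would do.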